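Compound 3 to compound 4: phenyl for cyclohexylmethyl

The source may report more compounds than this note shows. Statements on the series, on what has been measured and on what is new or still open speak of the compounds shown alone.

In an ADME assay on HOS cells (Homo sapiens) for cytotoxicity, read by luminescence and ATP content, with a stated time of 48 h (on this read-out lower numbers stand for higher toxicity in this test and higher numbers for lower toxicity in this test), compound 3 (`Nc1c(C(=O)NCc2ccc(F)cc2F)c(=O)n(O)c2ncc(CCCC3CCCCC3)cc12`) gives 27400 nM. For the measured compounds named here, compound 2 (`Nc1c(C(=O)NCc2ccc(F)cc2F)c(=O)n(O)c2ncc(CCCCCCOCc3ccccc3)cc12`) gives 14400 nM, and the single measured step is a 1.9-fold higher number from compound 2 to compound 3 (0.28 log units; within the scatter). Compound 1 (`COC(=O)CNc1c(C(=O)NCc2ccc(F)cc2F)c(=O)n(O)c2nc(OC)ccc12`) gives 12000 nM, a lower number than compound 3 by a gap beyond the scatter.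

Compound 4 (`Nc1c(C(=O)NCc2ccc(F)cc2F)c(=O)n(O)c2ncc(CCc3ccccc3)cc12`) differs from compound 3 as follows: phenyl in place of cyclohexylmethyl on a saturated chain carbon, two bonds along the chain from an aromatic carbon. This places phenyl in place of cyclohexylmethyl on a saturated chain carbon, two bonds along the chain from an aromatic carbon.

Going by the values given here, the only step bearing on this change, a 1.9-fold higher number from compound 2 to compound 3 (0.28 log units; within the scatter), also alters the chain end and stays within the scatter. No shift beyond the scatter is therefore expected in this assay. The expected step is a 1.1-fold lower number from compound 3 to compound 4 (0.04 log units; within the scatter). Compound 4 is estimated at 25000 nM, with an expected range of 10000 nM to 60000 nM.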

Compound 4, half-maximal cytotoxic concentration: 18000 nM
Compound 4: middle estimate off by 1.4-fold (0.14 log units), on the high side, within the range that was stated.
By their numbers in this assay, from the lowest: compounds 1, 2, 4 and 3 (each within the scatter of the next, the first and the last beyond it).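

In this assay, the step of a 1.5-fold lower number from compound 3 to compound 4 (0.18 log units; within the scatter) shows that phenyl in place of cyclohexylmethyl, on a saturated chain carbon, leaves the number within the scatter. For the compounds shown here, the step of a 1.3-fold higher number from compound 2 to compound 4 (0.10 log units; within the scatter) puts phenyl in place of 4-(benzyloxy)butyl, also within the scatter, so no step among compound 2, compound 3 and compound 4 separates these chain ends. No supporting data bear on these results.

Open, as far as these compounds go, is whether an amine or a carboxylic acid at the chain end would give a step beyond the scatter.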